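Swapping piperidin-1-yl for 4-methylpiperazin-1-yl on the shared core

The source may hold more compounds than are shown below. What is called first, only, known or untested is meant among the compounds shown, and "the series" means these compounds.

- compound 1 `CCNC(=O)c1noc(-c2cc(C(C)C)c(O)cc2O)c1-c1cc(CN(CC)CC)no1` in a functional assay on HCT-116 cells (Homo sapiens) for inhibition (on this read-out lower numbers stand for stronger inhibition and higher numbers for weaker inhibition), gives 38 nM
- compound 2 `CCNC(=O)c1noc(-c2cc(C(C)C)c(O)cc2O)c1-c1cc(CN2CCCCC2)no1` in this assay gives 93 nM

For the measured compounds named here, compound 2 (93 nM) holds the higher of the two numbers, which means the weaker inhibition, and compound 1 is its only neighbour. Compound 3 `CCNC(=O)c1noc(-c2cc(C(C)C)c(O)cc2O)c1-c1cc(CN2CCN(C)CC2)no1` keeps the shared core and differs from compound 2 in one group (4-methylpiperazin-1-yl in place of piperidin-1-yl on a saturated chain carbon bound to an aromatic carbon). Here 4-methylpiperazin-1-yl stands in place of piperidin-1-yl on a saturated chain carbon bound to an aromatic carbon, so the six-membered non-aromatic ring now has two hetero atoms instead of one.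

Going by the values given here, only one measured step bears on this, the exchange of diethylamino for piperidin-1-yl at the same place (a 2.4-fold higher number from compound 1 to compound 2 (0.39 log units; beyond the scatter)), and it was modest. That exchange is a different one, so it offers a scale and not a direction. In this assay a small change is therefore expected, probably none beyond the scatter, with a slight lean towards a higher number. The estimated value for compound 3 is 120 nM, with an expected range from 45 nM to 320 nM. This estimate means an expected (a 1.3-fold higher number from compound 2 to compound 3 (0.11 log units; within the scatter)).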

Compound 3, half-maximal inhibitory concentration: 340 nM
Beside the measured number, compound 3's estimate is 2.8-fold (0.45 log units) below it, and the stated range ends below it.
By their numbers in this assay, from the lowest: compound 1; then compound 2; then compound 3.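

In this assay, the position on a saturated chain carbon bound to an aromatic carbon proves sensitive to a change within the ring itself: with the six-membered non-aromatic ring kept, 4-methylpiperazin-1-yl in place of piperidin-1-yl gives a 3.7-fold higher number from compound 2 to compound 3 (0.56 log units; beyond the scatter). For the compounds shown here, until now, the only step at this position had exchanged an open diethylamino group for a ring, so the effect of a second hetero atom in that ring could not be seen. Across the three amines, the exchange of diethylamino for 4-methylpiperazin-1-yl gives an 8.9-fold higher number from compound 1 to compound 3 (0.95 log units; beyond the scatter), and both new steps run towards weaker inhibition, but no measurement at hand explains this trend.

Going by these compounds, it remains open whether the loss follows the second ring nitrogen or the methyl group it carries, and a piperazin-1-yl without that methyl group or a morpholin-4-yl at the same place would bear on this question. The compounds shown also leave open how smaller amines, such as dimethylamino or pyrrolidin-1-yl, would compare with diethylamino at this position.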